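The compounds below may be only part of what the source reports. "The series", "measured", "known", "first", "only" and "open" are said of these compounds alone.

Working notes on the series. Compound 3, structure `C=CC1=C(C(=O)NCc2ccc(Cl)cc2)C(c2ccc(OC)cc2)OC1`, carries a 4-chlorobenzyl group on the amide nitrogen. In a functional assay on QGY7701 cells (Homo sapiens) for cytotoxicity, read by MTT assay, with a stated time of 24 h (on this read-out higher numbers stand for weaker inhibition and lower numbers for stronger inhibition), compound 3 returns only a limit of the assay, > 100000 nM. Compound 2, `C=CC1=C(C(=O)NC(C)(C)C)C(c2ccc(OC)cc2)OC1`, is the tert-butyl analogue; in this assay compound 2 likewise returns only a limit, > 100000 nM. Compound 1, `C=CC1=C(C(=O)NCCC)C(c2ccc(F)cc2)OC1`, with a propyl amide and a 4-fluorophenyl substituent on the core, also returns only a limit in this assay, > 100000 nM. Among the measured compounds shown here, the single step between measured neighbours, a step that the two limits leave unreadable from compound 2 to compound 3, cannot be read for size, because of the limit of > 100000 nM in this assay, at which 3 of the 3 values shown sit. Compound 3 thus stands at the limit, as do the other two values shown.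

Compound 4, `C=CC1=C(C(=O)NCCC)C(c2ccc(OC)cc2)OC1`, differs from compound 3 in the amide substituent: ethyl in place of 4-chlorophenyl on a saturated chain carbon bound to an amide-type nitrogen. For the measured compounds named here, the only measured step that bears on a change at this position is a step that the two limits leave unreadable from compound 2 to compound 3, which gives no readable size. Compound 1 shows that the propyl amide, on a different aryl substituent, sits at the same limit. Going by the values given here, no step therefore supports an expectation of any measurable gain in this assay for compound 4. Compound 4 is expected to give 150000 nM, in the range 50000 nM to 600000 nM, which as a step that the limit leaves unreadable from compound 3 to compound 4 is expected to lie within the scatter.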

Compound 4, half-maximal inhibitory concentration: > 100000 nM
Compound 4 ended at the assay's limit; the forecaster's own chance of this, stated with the estimate: 85%; the middle value is on the limit's open side.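

Compound 4 returns only a limit in this assay and so its steps to compound 1, compound 2 and compound 3 cannot be read for size: (the limit of > 100000 nM in this assay, at which 4 of the 4 values shown sit). The compounds shown leave open whether in this assay any change to the amide substituent or to the aryl substituent on the shared core gives a value short of the limit.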